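A few compounds are considered here, and "the series" means these few. Any claim that something is new, unique, unknown or untested is made for them only; others in the source may bear on it.

Measured compounds in the series:
compound 1, `COc1ccc(-c2cc3c(OC)ccc(OC)c3nc2O)cc1`, 10000 nM
compound 2, `COc1ccc(-c2cc3c(OC)cc(OC)cc3n(C)c2=O)cc1`, 10000 nM

In a functional assay on U-373MG ATCC cells for cytotoxicity against U373 MG (Homo sapiens), read by colorimetric assay and MTT assay (on this read-out lower numbers stand for stronger inhibition and higher numbers for weaker inhibition), compound 2 gives 10000 nM, level with compound 1 at the digits shown, so nothing separates the two within the scatter. Compound 3, `COc1ccc(-c2cc3c(OC)cc(OC)cc3n(CC#N)c2=O)cc1`, differs from compound 2 by cyano in place of hydrogen on a saturated chain carbon bound to an aromatic nitrogen. Within the data shown here, no step between measured compounds is available, so the effect of this change cannot be read from the series itself. With both measured compounds level, no step beyond the scatter is expected for compound 3. Compound 3 is estimated at 10000 nM, with a range from 4000 nM to 25000 nM. The expected step of no change at the digits printed from compound 2 to compound 3 (within the scatter) is therefore none beyond the scatter.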

Compound 3, half-maximal inhibitory concentration: 10000 nM
Estimate against measurement, compound 3: no gap at the digits printed; the range from low to high includes it.
By their numbers in this assay, from the lowest: compounds 1, 2 and 3 (each within the scatter of the next).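

Cyano in place of hydrogen on a saturated chain carbon bound to an aromatic nitrogen gives, in this assay, no change at the digits printed from compound 2 to compound 3 (within the scatter). Among these compounds, this is the first one-place comparison, and it shows that going from methyl to cyanomethyl at this place leaves the read-out level. No supporting data bear on the reason for this result.

As far as these compounds go, whether an amine, a carboxylic acid or a longer chain at this place would separate from compound 2 stays open. From the compounds shown here alone, with all values level, it also stays open whether any change to the shared core moves the read-out in this assay.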